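This account rests on a few compounds, and the source may have more. Where it says the series, first, only, none or still open, it means among the compounds named here.

Measured in a functional assay on MKN-45 cells (Homo sapiens) for cytotoxicity; a higher number here means a weaker inhibitor, a lower number a stronger inhibitor:
compound 1 `COc1ccc(S(=O)(=O)N2CCc3cccc(NC(=O)c4cccs4)c32)cc1` gives 31 nM
compound 2 `COc1ccc(S(=O)(=O)N2CCc3cccc(NC(=O)c4ccc([N+](=O)[O-])cc4)c32)cc1` gives 95 nM
compound 3 `COc1ccc(S(=O)(=O)N2CCc3cccc(NC(=O)c4ccc(F)cc4)c32)cc1` gives 45 nM

Compound 3 stands second highest of the three numbers, with compound 1 nearest (a 1.5-fold higher number from compound 1 to compound 3 (0.16 log units; within the scatter)) and compound 2 furthest (a 2.1-fold lower number from compound 2 to compound 3 (0.32 log units; beyond the scatter)). Compound 4 `COc1ccc(S(=O)(=O)N2CCc3cccc(NC(=O)N(C)c4ccccc4)c32)cc1` differs from compound 3 by methyl(phenyl)amino in place of 4-fluorophenyl on a carbonyl carbon. Among the measured compounds shown here, no measured step exchanges an aryl group for an amino group on the carbonyl carbon; the steps that bear on it are the other exchanges at that carbon, a 3.1-fold higher number from compound 1 to compound 2 (0.49 log units; beyond the scatter) and a 1.5-fold higher number from compound 1 to compound 3 (0.16 log units; within the scatter), one modest and one within the scatter. A step of similar size in either direction, or none beyond the scatter, is therefore expected in this assay. Compound 4 is estimated at 60 nM, range 25 nM to 150 nM, which means an expected 1.3-fold higher number from compound 3 to compound 4 (0.12 log units; within the scatter).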

Compound 4, half-maximal inhibitory concentration: > 10000 nM
Compound 4 was reported as a limit (the forecaster's own chance of this, stated with the estimate: 5%); middle value at least 160-fold (2.22 log units) away from the limit.
By their numbers in this assay, from the lowest: compounds 1 and 3 (each within the scatter of the next); then compound 2. At a limit, above all of these: compound 4.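

At the carbonyl carbon, methyl(phenyl)amino gives an at least 220-fold higher number from compound 3 to compound 4 (2.34 log units; beyond the scatter), an at least 100-fold higher number from compound 2 to compound 4 (2.02 log units; beyond the scatter) and an at least 320-fold higher number from compound 1 to compound 4 (2.50 log units; beyond the scatter), all far larger than any exchange among thiophen-2-yl, 4-fluorophenyl and 4-nitrophenyl. The read-out for compound 4 is a limit, not a number: the limit of > 10000 nM in this assay, at which 1 of the 4 values shown sits. This position is therefore not indifferent to its substituent: the three aryl groups all give values in the nanomolar range, whereas this single amino group does not.

From the compounds shown here alone, it stays open whether the loss follows the amino nitrogen, the methyl or both. Phenylamino and benzyl on the same carbonyl carbon would separate these.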